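The source may report more compounds than this note shows. Statements on the series, on what has been measured and on what is new or still open speak of the compounds shown alone.

Going by the values given here, compound 1 `CCc1cccc(C[C@H](O)/C=C/[C@H]2COC(=O)N2CCSCCCC(=O)O)c1` is the one compound here with a numerical reading in an assay on CHO cells for displacement of a labelled ligand from prostaglandin E2 receptor EP1 subtype (Mus musculus), read by scintillation counting, with a stated time of 20 min (on this read-out lower numbers stand for stronger inhibition and higher numbers for weaker inhibition), where compound 1 gives 2400 nM. Compound 2 `O=C(O)CCCSCCN1C(=O)SC[C@@H]1/C=C/[C@@H](O)Cc1ccccc1` gives in this assay only a limit, > 10000 nM. Compound 3 `COCc1cccc(C[C@H](O)/C=C/[C@H]2CSC(=O)N2CCSCCCC(=O)O)c1` likewise gives in this assay only a limit, > 10000 nM. Among the compounds with values here, the single change joining two measured compounds, a step that the two limits leave unreadable from compound 2 to compound 3, sits between two such limits the limit of > 10000 nM in this assay, at which 2 of the 3 values shown sit, and so its size cannot be read. Compound 4 `O=C(O)CCCSCCN1C(=O)OC[C@@H]1/C=C/[C@@H](O)Cc1cccc(-c2ccccc2)c1` arises from compound 1 by one change (phenyl in place of ethyl on an aromatic carbon). Within the data shown here, no measured step touches that change, so no direction beyond the usual scatter is supported. Compound 4 is therefore expected to stand at 3000 nM (from 600 nM to 15000 nM), which means an expected step of a 1.3-fold higher number from compound 1 to compound 4 (0.10 log units; within the scatter).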

Compound 4, inhibition constant: > 10000 nM
Compound 4 was reported as a limit (the forecaster's own chance of this, stated with the estimate: 35%); middle value at least 3.3-fold (0.52 log units) from the limit.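

Placing phenyl instead of ethyl on this aromatic carbon, meta to a large group, gives the first step here that starts from a measured number: in this assay it is an at least 4.1-fold higher number from compound 1 to compound 4 (0.61 log units; beyond the scatter). This position therefore does not treat every carbon group alike, and ethyl reads better here than phenyl. The value of compound 4 is a limit and not a number: the limit of > 10000 nM in this assay, at which 3 of the 4 values shown sit.

Still open, on these data alone, is how a propyl chain, a methoxy group or an amine on this carbon would read against compound 1. It is also unclear whether any group here can give a lower number than ethyl.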